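Bromo to Methoxy on a Long-Lived Core

The compounds below may be only part of what the source reports. "The series", "measured", "known", "first", "only" and "open" are said of these compounds alone.

Two compounds that share one core have been run in a physicochemical assay for pharmacokinetics; a lower number here means that the compound disappears faster, a higher number that the compound lasts longer. Compound 1, `CC(NC(=O)N1C(=O)c2ccccc2S1(=O)=O)c1ccccc1`, returns only a limit of the assay in this assay, namely > 166 h. Compound 2, `O=C(NCc1ccccc1Br)N1C(=O)c2ccccc2S1(=O)=O`, likewise returns only a limit of the assay in this assay, namely > 166 h. For the measured compounds named here, compound 2 therefore stands where every value shown stands, at the limit of > 166 h in this assay, at which 2 of the 2 values shown sit, and no step between measured compounds can be drawn from two limits. The change that leads to compound 3, `COc1ccccc1CNC(=O)N1C(=O)c2ccccc2S1(=O)=O`, is methoxy in place of bromo on an aromatic carbon. Going by the values given here, with no measured step to guide the expectation, a step of no size beyond the usual scatter is expected, in no particular direction, a step that the limit leaves unreadable from compound 2 to compound 3. Compound 3 is accordingly estimated at 200 h, with a range from 60 h to 600 h, and it is expected most likely to be reported once more only as a limit.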

Compound 3, half-life: > 166 h
Compound 3: a limit, no number; the forecaster's own chance of this, stated with the estimate: 75%; the middle value is on the limit's open side.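

For the compounds shown here, compound 2 and compound 3 are both reported only as limits in this assay, so no step between them can be read. The compounds shown leave open how long any of them actually lasts, and whether methoxy in place of bromo changes that at all.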